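This account rests on a few compounds, and the source may have more. Where it says the series, first, only, none or still open, it means among the compounds named here.

Compound 1 `CC(C)c1ccc(-c2cc(-c3ccc(OCc4cn(Cc5ccc(Br)cc5)nn4)cc3O)nc(N)n2)cc1`: "not determined" (no result reported)
Compound 2 `Nc1nc(-c2ccc(OCc3cn(Cc4ccccc4)nn3)cc2O)cc(-c2cccc3ccccc23)n1`: 71300 nM
Compound 3 `Nc1nc(-c2ccccc2)cc(-c2ccc(OCc3cn(Cc4ccc(Br)cc4)nn3)cc2O)n1`: > 100000 nM

In an ADME assay on cells (Macrophage) for cytotoxicity, read by resazurin assay, with a stated time of 48 h (on this read-out lower numbers stand for higher toxicity in this test and higher numbers for lower toxicity in this test), compound 3 gives only a limit, > 100000 nM, and not a number. It therefore has no exact position among these compounds. Compound 1 offers no comparison, since no result was reported for it.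

Compound 4 `Nc1nc(-c2ccc(OCc3cn(Cc4ccc(Br)cc4)nn3)cc2O)cc(-c2cccc3ccccc23)n1` differs from compound 3 by having naphthalen-1-yl in place of phenyl on an aromatic carbon. Among the compounds with values here, no measured pair of compounds isolates this exchange, so any expectation rests on thin evidence. The closest guide is compound 2, which also carries naphthalen-1-yl and gives 71300 nM in this assay.

On that basis, a modest move toward lower numbers, meaning somewhat higher toxicity in this test, is expected, with an estimated at least 1.4-fold lower number from compound 3 to compound 4 (0.15 log units; that floor lies within the scatter). A result reported only as a limit would also be no surprise. The estimate for compound 4 is 70000 nM, with an expected range from 30000 nM to 130000 nM.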

Compound 4, half-maximal cytotoxic concentration: > 100000 nM
Compound 4: no number, only a limit (the forecaster's own chance of this, stated with the estimate: 35%); middle value at least 1.4-fold (0.15 log units) away from the limit.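

In this assay compound 4 gives > 100000 nM, which is a limit and not a number, and with a limit on both sides the exchange of phenyl for naphthalen-1-yl cannot be read. Within the data shown here, the one step that can be read is bromo in place of hydrogen on an aromatic carbon, with an at least 1.4-fold higher number from compound 2 to compound 4 (0.14 log units; that floor lies within the scatter). Adding naphthalen-1-yl to the bromo-bearing compound therefore did not bring the read-out down to a number, and the compounds now gather at the top of the range: the limit of > 100000 nM in this assay, at which 2 of the 4 values shown sit.

Going by these compounds, how far compound 4 lies past its limit remains open, and so does whether the bromo step exceeds the scatter. Also open, on these data alone, is how an amine or a carboxylic acid in place of that bromo would read in this assay.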